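A few compounds are considered here, and "the series" means these few. Any claim that something is new, unique, unknown or untested is made for them only; others in the source may bear on it.

Values measured in an ADME assay on microsomes from liver (Mus musculus) for metabolic stability, read by LC-MS, using NADPH, with a stated time of 10 min, tested at 0.5 uM; a lower number here means that less of the compound is left, a higher number that more of the compound is left:

- Compound 1 `COC(=O)Nc1cc(-c2ccc(OC[C@@](C)(N)CC(C)C)cn2)ccn1`: 93%
- Compound 2 `COC(=O)Nc1cc(-c2ccc(OC[C@@](C)(N)CC(C)C)nc2)ccn1`: 79%
- Compound 3 `COC(=O)Nc1cc(-c2cc(Cl)c(OC[C@@](C)(N)CC(C)C)cn2)ccn1`: 87%

Compound 1 and compound 2 both lie within the scatter of compound 3, which gives 87%. Compound 4 `COC(=O)Nc1cc(-c2cc(C)c(OC[C@@](C)(N)CC(C)C)cn2)ccn1` carries methyl in place of chloro on an aromatic carbon. Within the data shown here, the one measured step at this place is chloro in place of hydrogen, a number 6 percentage points lower from compound 1 to compound 3 (within the scatter). Among the measured compounds shown here, no measured compound carries methyl there, so this step is only a loose guide. No change beyond the scatter is expected in this assay, and the estimated step is a number 2 percentage points lower from compound 3 to compound 4 (within the scatter). Compound 4 is expected at 85%, with an estimated range of 72% to 95%.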

Compound 4, percent of the compound remaining: 99%
Compound 4: middle estimate off by 14 percentage points, on the low side, and the stated range ends below it.
By their numbers in this assay, from the lowest: compounds 2, 3, 1 and 4 (each within the scatter of the next, the first and the last beyond it).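

In this assay, methyl in place of chloro on this aromatic carbon, ortho to the (2-amino-2,4-dimethylpentyl)oxy group, gives a number 12 percentage points higher from compound 3 to compound 4 (beyond the scatter), so two groups of one heavy atom each are told apart at this position. Methyl in place of hydrogen gives a number 6 percentage points higher from compound 1 to compound 4 (within the scatter), so methyl and hydrogen are not told apart here. No measurement given here accounts for the gap between chloro and methyl. Going by these compounds, whether fluoro, methoxy or a longer chain at this place would stand with methyl or with chloro stays open, as does whether methyl would act alike on the core of compound 2.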